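From 3-Chlorophenyl to 4-Chlorophenyl: an Untested Shift

The source may hold more compounds than are shown below. What is called first, only, known or untested is meant among the compounds shown, and "the series" means these compounds.

Of the compounds shown here, two have been measured in an ADME assay on HEK-293T cells (Homo sapiens) for cytotoxicity, read by CCK-8 assay, with a stated time of 48 h; on this read-out lower numbers stand for stronger inhibition and higher numbers for weaker inhibition. Compound 1 `O=S(=O)(NCCNC(=S)Nc1cccc(Cl)c1)c1ccc(-c2ccccc2OCc2cccc(O)c2)s1` gives 17400 nM in this assay, and compound 2 `O=S(=O)(NCCNC(=S)Nc1cccc(Cl)c1)c1ccc(-c2ccccc2OCc2ccccc2)s1` gives 10200 nM. Among the measured compounds shown here, the single measured step, a 1.7-fold lower number from compound 1 to compound 2 (0.23 log units; within the scatter), is hydrogen in place of hydroxy on an aromatic carbon. Compound 2 therefore holds the lower of the two numbers, though its gap to compound 1 lies within the scatter, so the two cannot be told apart. Compound 3 `O=S(=O)(NCCNC(=S)Nc1ccc(Cl)cc1)c1ccc(-c2ccccc2OCc2ccccc2)s1` has not yet been measured; it differs from compound 2 by 4-chlorophenyl in place of 3-chlorophenyl on an amide-type nitrogen. For the measured compounds named here, no measured step touches this part of the molecule, so the data give no direction for the change, and the one known step, which sits elsewhere and stays within the scatter, gives no hint of a large effect. The step of a 1.0-fold lower number from compound 2 to compound 3 (0.01 log units; within the scatter) is therefore expected to stay within the scatter. Compound 3 is estimated at 10000 nM, likely between 4000 nM and 25000 nM.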

Compound 3, half-maximal inhibitory concentration: 12100 nM
Beside the measured number, compound 3's estimate is 1.2-fold (0.08 log units) below it, within the range that was stated.
By their numbers in this assay, from the lowest: compounds 2, 3 and 1 (each within the scatter of the next).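

Among the compounds shown here, this is the first measured step at the group on the amide-type nitrogen: in this assay, 4-chlorophenyl in place of 3-chlorophenyl gives a 1.2-fold higher number from compound 2 to compound 3 (0.07 log units; within the scatter) on an otherwise unchanged molecule. For this one pair, the read-out cannot tell the two chlorophenyl groups apart, so this change shows no measurable effect on cytotoxicity in these cells. No available measurement offers an explanation for this result.

Going by these compounds, it remains open whether a group of a different kind at this place, such as 4-methoxyphenyl, a plain phenyl or a butyl chain, would give a number clearly apart from these. On these data alone, it is also open whether 4-chlorophenyl would give a similar result on the core of compound 1, which carries the hydroxy group.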